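Benzoyl for Benzyl on the Ring Nitrogen

A few compounds are considered here, and "the series" means these few. Any claim that something is new, unique, unknown or untested is made for them only; others in the source may bear on it.

Within the data shown here, compound 1 `CCCCNc1nc(N)nc2c1CCN(Cc1ccccc1)C2` is one of three compounds measured in an assay on HEK293 cells for agonist activity at Toll-like receptor 8 (Homo sapiens), read by a luciferase reporter, with a stated time of 6 h; on this read-out lower numbers stand for an effect already at smaller amounts and higher numbers for an effect only at larger amounts of compound; there compound 1 gives 0.4 uM. Among the three numbers it stands second highest. Its nearest neighbour is compound 3 `CCCCNc1nc(N)nc2c1CN(C(C)=O)CC2`, which gives 0.5 uM, a gap that falls within the scatter. Far apart from both is compound 2 `CCCCNc1nc(N)nc2c1CN(C)CC2`, which gives 0.03 uM, the lowest number of the set. Among the measured compounds shown here, the only step between measured compounds that differ in one place is a 17-fold higher number from compound 2 to compound 3 (1.22 log units; beyond the scatter), where an acetyl replaces a methyl on the amine nitrogen in a ring: turning that ring amine into an amide went with a large rise in the number.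

Compound 4 `CCCCNc1nc(N)nc2c1CCN(C(=O)c1ccccc1)C2` differs from compound 1 in one place: benzoyl in place of benzyl on an amine nitrogen in a ring. For the measured compounds named here, this is the same kind of move, an acyl group in place of an alkyl group on the amine nitrogen in a ring, and the single step that bears on it, a 17-fold higher number from compound 2 to compound 3 (1.22 log units; beyond the scatter), was large and upward. A rise of comparable size is therefore expected for compound 4, namely a 10-fold higher number from compound 1 to compound 4 (1.00 log units; beyond the scatter). Compound 4 is expected to give 4 uM, with a likely range from 1 uM to 20 uM.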

Compound 4, minimum effective concentration: 0.8 uM
The estimate for compound 4 lay 5.0-fold (0.70 log units) above the measured number; measured number outside the range, below it.
By their numbers in this assay, from the lowest: compound 2; then compounds 1, 3 and 4 (each within the scatter of the next).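

In this assay the exchange of benzyl for benzoyl on the amine nitrogen in a ring gives a 2.0-fold higher number from compound 1 to compound 4 (0.30 log units; within the scatter) and so leaves compound 1 and compound 4 indistinguishable on this read-out, even though the entering group brings a carbonyl and a hydrogen-bond acceptor that the leaving group lacks. The earlier step, a 17-fold higher number from compound 2 to compound 3 (1.22 log units; beyond the scatter), had suggested that an acyl group on such a nitrogen goes with a large rise, but the new step shows that this does not hold in every pair: compound 3 follows that pattern and compound 4 goes against it. Nothing shown here accounts for the contrast between the two steps.

Going by these compounds, the two pairs differ in both their cores and their groups, so it remains open whether the contrast follows the core of compound 1 or the benzene ring carried by both benzyl and benzoyl. Also open, on these data alone, is how that core would respond to a methyl, an acetyl, a phenethyl group or a plain hydrogen on the same nitrogen, which would place the result for compound 4 on a firmer footing.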